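Moving the nitro group on the piperazine aryl substituent

The source may hold more compounds than are shown below. What is called first, only, known or untested is meant among the compounds shown, and "the series" means these compounds.

Compound 3 `CC#CC(CC(=O)O)c1ccc(OCc2ccc(C(=O)N3CCN(c4ccc([N+](=O)[O-])cc4)CC3)s2)cc1` carries a 4-nitrophenyl on the ring amine nitrogen; in a functional assay on HEK293 cells for agonist activity at Free fatty acid receptor 1 (Homo sapiens), read by fluorescence and calcium flux (on this read-out lower numbers stand for an effect already at smaller amounts and higher numbers for an effect only at larger amounts of compound), compound 3 gives 231 nM, the lowest of the two numbers shown. Compound 1 `CC#CC(CC(=O)O)c1ccc(OCc2ccc(C(=O)N3CCN(C4CCCCC4)CC3)s2)cc1` gives 820 nM, and a 3.5-fold lower number from compound 1 to compound 3 (0.55 log units; beyond the scatter). Compound 2 `CC#CC(CC(=O)O)c1ccc(OCc2ccc(C(=O)N3CCN(c4ccncc4)CC3)s2)cc1` gives only a limit, > 5000 nM, which is the limit of > 5000 nM in this assay, at which 1 of the 3 values shown sits. Measured from that limit, an at least 21-fold lower number from compound 2 to compound 3 (1.33 log units; beyond the scatter), while an at least 6.0-fold higher number from compound 1 to compound 2 (0.78 log units; beyond the scatter).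

Compound 4 `CC#CC(CC(=O)O)c1ccc(OCc2ccc(C(=O)N3CCN(c4ccccc4[N+](=O)[O-])CC3)s2)cc1` differs from compound 3 in one respect: 2-nitrophenyl in place of 4-nitrophenyl on an amine nitrogen in a ring. None of the three measured steps bears directly on this change: each exchanges one whole group for another, whereas here the same atoms are joined differently. The measured steps show that the nature of the group on the ring nitrogen matters, with the 4-nitrophenyl of compound 3 giving the lowest number, but they say nothing about rearranging that group. Compound 4 is therefore expected to give a step of small size, leaning toward a higher number, a 1.9-fold higher number from compound 3 to compound 4 (0.29 log units; within the scatter). Compound 4 is estimated at 450 nM, within a range of 150 nM to 1500 nM.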

Compound 4, half-maximal effective concentration: 94 nM
Compound 4: middle estimate off by 4.8-fold (0.68 log units), on the high side; measured number outside the range, below it.
By their numbers in this assay, from the lowest: compound 4; then compound 3; then compound 1. At a limit, above all of these: compound 2.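

Moving the nitro group on the same phenyl ring shifts the read-out in this assay, with a 2.5-fold lower number from compound 3 to compound 4 (0.39 log units; beyond the scatter), so this position responds to where the nitro group sits and not only to which group stands on the ring nitrogen. Against the cyclohexyl, the 2-nitrophenyl gives an 8.7-fold lower number from compound 1 to compound 4 (0.94 log units; beyond the scatter), and it has the lowest number of the series. Against the pyridin-4-yl it gives an at least 53-fold lower number from compound 2 to compound 4 (1.72 log units; beyond the scatter), but that step starts from a limit and not from a number: the limit of > 5000 nM in this assay, at which 1 of the 4 values shown sits.

From the compounds shown here alone, whether the preference for the 2-nitrophenyl depends on the nitro group itself stays open, as an amine or a nitrile in its place on the phenyl ring could give a different order. Going by these compounds, how a plain phenyl on the ring nitrogen would compare also remains unknown.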